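Isopropyl for methyl on the sulfonyl, tolerance expected unchanged

The source may hold more compounds than are shown below. What is called first, only, known or untested is meant among the compounds shown, and "the series" means these compounds.

Measured so far:
compound 1 `CS(=O)(=O)CCCn1c(Cn2cc(S(C)(=O)=O)c3ccccc32)nc2cc(Cl)ccc21` — > 100000 nM
compound 2 `CS(=O)(=O)CCCn1c(Cn2cc(S(C)(=O)=O)c3cc(F)ccc32)nc2cc(Cl)ccc21` — > 100000 nM

Two compounds on a shared core have been examined in an ADME assay on HEp-2 cells (Homo sapiens) for cytotoxicity, with a stated time of 4 days; a higher number here means that more compound is tolerated, a lower number that less compound is tolerated. Compound 1 `CS(=O)(=O)CCCn1c(Cn2cc(S(C)(=O)=O)c3ccccc32)nc2cc(Cl)ccc21` gives > 100000 nM, which is a limit of the assay and not a number. Compound 2 `CS(=O)(=O)CCCn1c(Cn2cc(S(C)(=O)=O)c3cc(F)ccc32)nc2cc(Cl)ccc21` gives > 100000 nM, again a limit rather than a measured number. Within the data shown here, compound 1 therefore stands at the limit of > 100000 nM in this assay, at which 2 of the 2 values shown sit, and the only measured step that starts from it, fluoro in place of hydrogen on an aromatic carbon, is a step that the two limits leave unreadable from compound 1 to compound 2.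

Compound 3 `CC(C)S(=O)(=O)c1cn(Cc2nc3cc(Cl)ccc3n2CCCS(C)(=O)=O)c2ccccc12` is not yet measured. It differs from compound 1 by isopropyl in place of methyl on a sulfonyl sulfur. Among the measured compounds shown here, no measured step touches the sulfonyl sulfur, and the one step that is known cannot be read in size or direction, so the measured data give no guide to a change. In this assay the expected step is a number no higher from compound 1 to compound 3 (the limit leaves the size open), none beyond the scatter. Compound 3 is estimated at 100000 nM, in a range from 50000 nM to 200000 nM, most probably reported again only as a limit.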

Compound 3, half-maximal cytotoxic concentration: > 100000 nM
Compound 3 gave a limit, no number; the forecaster's own chance of this, stated with the estimate: 80%; the middle value lies on the limit itself.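

In this assay compound 3 gives > 100000 nM, a limit and not a number. Among these compounds, no step from compound 1 to compound 2 or to compound 3 can be read, and all three compounds stand at one point: the limit of > 100000 nM in this assay, at which 3 of the 3 values shown sit. The compounds shown leave open how much of each is actually tolerated, and whether either change alters that.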